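This account rests on a few compounds, and the source may have more. Where it says the series, first, only, none or still open, it means among the compounds named here.

Compound 1 `O=C(c1cccc(Cl)c1)N1CCC(NS(=O)(=O)c2cc(S(=O)(=O)c3ccccc3)ccc2C(F)(F)F)CC1` gives 870 nM in an assay on U2OS cells for inhibition of secreted frizzled-related protein 1 (Homo sapiens), read by a luciferase reporter, with a stated time of 18 h; on this read-out lower numbers stand for an effect already at smaller amounts and higher numbers for an effect only at larger amounts of compound.
Compound 2 `CN(C)c1ccc(C(=O)N2CCC(NS(=O)(=O)c3cc(S(=O)(=O)c4ccccc4)ccc3C(F)(F)F)CC2)cn1` gives 70 nM.
Compound 3 `O=C(O)c1ccc(S(=O)(=O)N2CCC(NS(=O)(=O)c3cc(S(=O)(=O)c4ccccc4)ccc3C(F)(F)F)CC2)cc1` gives 110 nM.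

All three share one core and differ only in the group carried by the amine nitrogen of the six-membered non-aromatic ring. Compound 3 stands second highest of the three numbers: its step from compound 2 is a 1.6-fold higher number from compound 2 to compound 3 (0.20 log units; within the scatter), so those two cannot be ranked, while its step from compound 1 is a 7.9-fold lower number from compound 1 to compound 3 (0.90 log units; beyond the scatter). The largest step seen, a 12-fold lower number from compound 1 to compound 2 (1.09 log units; beyond the scatter), also comes from changing this same group. Compound 4 `CC(C)(O)CCN1CCC(NS(=O)(=O)c2cc(S(=O)(=O)c3ccccc3)ccc2C(F)(F)F)CC1` alters the same position again: 3-hydroxy-3-methylbutyl in place of (4-carboxyphenyl)sulfonyl on an amine nitrogen in a ring. The measured steps at this position all exchange one aromatic group for another; none exchanges an aromatic group for an open chain, so the data give no direct guide for the direction of this assay here. Because a 7.9-fold lower number from compound 1 to compound 3 (0.90 log units; beyond the scatter) shows that an aromatic group at this position was well tolerated, a step to a higher number is expected, a 5.5-fold higher number from compound 3 to compound 4 (0.74 log units; beyond the scatter). Compound 4 is estimated at 600 nM, with a range from 150 nM to 3000 nM.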

Compound 4, half-maximal effective concentration: 630 nM
Beside the measured number, compound 4's estimate is 1.1-fold (0.02 log units) below it; measured number inside the range.
By their numbers in this assay, from the lowest: compounds 2 and 3 (each within the scatter of the next); then compounds 4 and 1 (each within the scatter of the next).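

Compound 4 brings an open chain onto the amine nitrogen of the six-membered ring, and in this assay this gives a higher number than either of the two lowest compounds, with a 5.7-fold higher number from compound 3 to compound 4 (0.76 log units; beyond the scatter) and a 9.0-fold higher number from compound 2 to compound 4 (0.95 log units; beyond the scatter) as the steps. Against the remaining aromatic group, the result is a 1.4-fold lower number from compound 1 to compound 4 (0.14 log units; within the scatter) and the two compounds cannot be ranked, so an aromatic ring at this position does not by itself ensure a low number. The change also removes the carbonyl or sulfonyl on that nitrogen, so the loss of the ring and the loss of this link cannot be told apart.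

No measured evidence accounts for these steps. Still open, on these data alone, is how a 3-hydroxy-3-methylbutyl chain would compare with a longer chain, or with a chain ending in an amine or a carboxylic acid.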